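The source may report more compounds than this note shows. Statements on the series, on what has been measured and on what is new or still open speak of the compounds shown alone.

Measured so far:
compound 1, `Cc1cc(NCCN2CCN(C)CC2)nc2ccc(NC(=O)c3ccc(Cl)c(Cl)c3)cc12`, 1700 nM
compound 2, `CCN1CCN(c2cc(C)c3cc(NC(=O)c4cccc(Br)c4)ccc3n2)CC1`, 11600 nM
compound 3, `CCN1CCN(c2cc(C)c3cc(NC(=O)c4ccccc4)ccc3n2)CC1`, 14200 nM

All three were tested in a functional assay on MCF7 cells (Homo sapiens) for antiproliferative activity, read by MTT assay, with a stated time of 72 h; a lower number here means a stronger inhibitor, a higher number a weaker inhibitor. Compound 1 gives the lowest number of the three; compound 2 lies a good way above it, and compound 3 further still, both gaps beyond the scatter, so compound 1 is the strongest inhibitor of this set. Among the compounds with values here, the only single-point step among the measured compounds is a 1.2-fold higher number from compound 2 to compound 3 (0.09 log units; within the scatter), which concerns the benzamide ring and says nothing about the side chain.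

Compound 4, `CCNc1cc(C)c2cc(NC(=O)c3ccc(Cl)c(Cl)c3)ccc2n1`, is compound 1 with one change: hydrogen in place of 4-methylpiperazin-1-yl on a saturated chain carbon, two bonds along the chain from a nitrogen on an aromatic ring. Within the data shown here, no measured pair covers the removal of this ring from the chain, so the expectation rests only on where compound 1 stands and on the fact that compounds 2 and 3, which carry a different arrangement of the same kind of ring, give much higher numbers. Cutting the ring away is therefore expected to cost some potency, most likely a moderate rise in the number, with the expected step from compound 1 being a 2.9-fold higher number from compound 1 to compound 4 (0.47 log units; beyond the scatter). Compound 4 is estimated at 5000 nM, with a range from 1500 nM to 16000 nM.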

Compound 4, half-maximal inhibitory concentration: 48600 nM
For compound 4 the middle estimate is 9.7-fold (0.99 log units) below the measured one, and the stated range ends below it.
By their numbers in this assay, from the lowest: compound 1; then compounds 2 and 3 (each within the scatter of the next); then compound 4.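

In this assay, the new result is a 29-fold higher number from compound 1 to compound 4 (1.46 log units; beyond the scatter), a large step that comes from replacing the 4-methylpiperazin-1-yl group with hydrogen, which turns the (2-(4-methylpiperazin-1-yl)ethyl)amino side chain into ethylamino. The earlier single-change step, a 1.2-fold higher number from compound 2 to compound 3 (0.09 log units; within the scatter), stayed within the scatter and concerned a bromo group on an aromatic carbon, so it said nothing about this chain. This new step shows that, with the rest of compound 1 held constant, the number depends strongly on this ring being present, though no measurement here explains why the loss occurs.

As far as these compounds go, what remains open is whether the full 4-methylpiperazin-1-yl group is required or a smaller or different group could stand in its place, such as a dimethylamino group or a morpholine ring on the same chain. From the compounds shown here alone, it is also open how the number would respond to a longer chain carrying the same ring, which would show whether the distance from the shared core matters as well as the ring itself.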